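Fluorinated aryl ureas tested in a whole-plant rice assay

A few compounds are considered here, and "the series" means these few. Any claim that something is new, unique, unknown or untested is made for them only; others in the source may bear on it.

Compound 1 `C[C@@H](NC(=O)Nc1cccc(F)c1)c1ccccc1`, compound 2 `C[C@@H](NC(=O)Nc1ccc(F)cc1)c1ccccc1` and compound 3 `C[C@@H](NC(=O)Nc1ccc(F)cc1F)c1ccccc1` were examined in an ADME assay on the whole organism with Oryza sativa as the target, tested at 10 uM; a higher number here means a weaker effect of the compound at the concentration tested, a lower number a stronger effect. Compound 1 gives 84%, compound 2 gives 92% and compound 3 gives 93%. The difference between the cores of compound 1 and compound 2 is not broken down here. Compound 3 arises from compound 2 by fluoro in place of hydrogen on an aromatic carbon, and this step gave a number 1 percentage points higher from compound 2 to compound 3 (within the scatter). Compound 4 `C[C@@H](NC(=O)Nc1cc(F)cc(F)c1)c1ccccc1` arises from compound 1 by the same kind of change, (fluoro in place of hydrogen on an aromatic carbon), though here the entering fluoro sits meta to a large group rather than ortho to it. Because the earlier step of a number 1 percentage points higher from compound 2 to compound 3 (within the scatter) stayed within the scatter, compound 4 is expected to stay close to compound 1, with an estimated step of a number 2 percentage points higher from compound 1 to compound 4 (within the scatter). The estimate for compound 4 in this assay is 86%, expected between 76% and 95%.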

Compound 4, a percentage reported as activity, at one concentration (the size of the read-out at that concentration, not a potency): 96%
Compound 4: the middle estimate sits 10 percentage points below what was measured, outside the stated range (above it).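

On the core of compound 1, fluoro in place of hydrogen on an aromatic carbon gave in this assay a number 12 percentage points higher from compound 1 to compound 4 (beyond the scatter). Set beside the earlier step, this one cannot be told apart from it, so the two cores give no firm sign that the change behaves differently from one to the other: the same change on two cores in this assay, a number 1 percentage points higher (within the scatter) from compound 2 to compound 3 and a number 12 percentage points higher (beyond the scatter) from compound 1 to compound 4, 11 percentage points apart, within the scatter of two such steps. Yet two pairs do not show that the step carries over with a fixed size either, and in compound 4 the entering fluoro sits meta to a fluoro group, so core and place cannot be separated here.

The compounds shown leave open how a chloro group, a methoxy group or an amine on the same aromatic ring would read in this assay. They also leave open what a longer chain in place of the methyl group on the urea side would do.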